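A Halogen Swap Tested Against Breast Cancer Cells

A few compounds are considered here, and "the series" means these few. Any claim that something is new, unique, unknown or untested is made for them only; others in the source may bear on it.

Three compounds built on one shared core were tested in a functional assay on MDA-MB-231 cells (Homo sapiens) for cytotoxicity, read by MTT assay, with a stated time of 48 h; on this read-out higher numbers stand for weaker inhibition and lower numbers for stronger inhibition. Compound 1 `O=C(O)CN1C(=O)/C(=C/c2nc3ccccc3n2Cc2ccc(F)cc2)SC1=S` gives 2620 nM. Compound 2 `O=C(O)CN1C(=O)/C(=C/c2nc3ccccc3n2Cc2ccc(Cl)cc2)SC1=S` gives 5580 nM in this assay. Compound 3 `Cc1ccc(Cn2c(/C=C3\SC(=S)N(CC(=O)O)C3=O)nc3ccc(Cl)cc32)cc1` gives 3960 nM in this assay, a number that sits within the usual scatter of both compound 1 and compound 2. How the core of compound 3 differs from that of compound 2 is not broken down here.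

Compound 2 and compound 1 differ in one place: fluoro in place of chloro on an aromatic carbon. That single change gave a 2.1-fold lower number from compound 2 to compound 1 (0.33 log units; beyond the scatter).

Compound 4 `Cc1ccc(Cn2c(/C=C3\SC(=S)N(CC(=O)O)C3=O)nc3ccc(F)cc32)cc1` has not yet been measured. It differs from compound 3 in one place: fluoro in place of chloro on an aromatic carbon. Going by the values given here, this is the same kind of change as the one from compound 2 to compound 1, but not the same: in compound 1 the fluoro sits para to a large group, whereas in compound 4 it sits on a ring that is part of a fused or bridged system of two rings, meta to a fused ring and para to a fused ring.

A step in the same direction, though of uncertain size, is expected, a 1.5-fold lower number from compound 3 to compound 4 (0.18 log units; within the scatter), because the earlier swap gave a 2.1-fold lower number from compound 2 to compound 1 (0.33 log units; beyond the scatter) at a different place. Compound 4 is therefore estimated to give 2600 nM, with a plausible range from 1200 nM to 6000 nM.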

Compound 4, half-maximal inhibitory concentration: 3860 nM
Compound 4: the middle estimate sits 1.5-fold (0.17 log units) below what was measured; the range from low to high includes it.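

On the core of compound 3, fluoro in place of chloro gave a 1.0-fold lower number from compound 3 to compound 4 (0.01 log units; within the scatter), so on this core the swap produced no difference that can be told apart from the ordinary spread of repeated measurements. Set beside the earlier swap, the two results are not clearly different from each other: the same change on two cores in this assay, a 2.1-fold lower number (0.33 log units; beyond the scatter) from compound 2 to compound 1 and a 1.0-fold lower number (0.01 log units; within the scatter) from compound 3 to compound 4, 2.1-fold (0.32 log units) apart, within the scatter of two such steps. This means the series neither shows that the clear step seen with compound 1 carries over to the other core nor shows that it fails to, and a single pair on each core, with the swap at a different place in each, is too little to decide either way.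

The compounds shown leave open whether a group other than the two halogens, such as a nitrile, a methoxy group or an amine, would shift the number at either place. Also open, as far as these compounds go, is whether fluoro in place of chloro would give the same step at both places on a single core.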